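Dimethylamino for Amino, Repeated on a Second Core

The compounds below may be only part of what the source reports. "The series", "measured", "known", "first", "only" and "open" are said of these compounds alone.

Three compounds have been measured in an assay on thoracic aorta for binding affinity to Endothelin-1 receptor (Rattus norvegicus); on this read-out lower numbers stand for stronger inhibition and higher numbers for weaker inhibition:

compound 1, `Cc1noc(NS(=O)(=O)c2cccc3cc(N)ccc23)c1C`: 2400 nM
compound 2, `Cc1noc(NS(=O)(=O)c2cccc3cc(N(C)C)ccc23)c1C`: 840 nM
compound 3, `Cc1noc(NS(=O)(=O)c2cccc3ccc(N)cc23)c1C`: 1450 nM

Compound 2 differs from compound 1 by dimethylamino in place of amino on an aromatic carbon; this change brought a 2.9-fold lower number from compound 1 to compound 2 (0.46 log units; beyond the scatter). Compound 3 has the same atoms as compound 1 joined differently, and the difference between the two cores is not broken down here. The values of compound 3 and compound 1 lie within the scatter of each other, as do those of compound 3 and compound 2.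

Compound 4, `Cc1noc(NS(=O)(=O)c2cccc3ccc(N(C)C)cc23)c1C`, is not yet measured. It arises from compound 3 by dimethylamino in place of amino on an aromatic carbon, the same change that led from compound 1 to compound 2. Because a 2.9-fold lower number from compound 1 to compound 2 (0.46 log units; beyond the scatter) was seen for that change, a step of about a 2.6-fold lower number from compound 3 to compound 4 (0.42 log units; beyond the scatter) is expected from compound 3 to compound 4. Compound 4 is therefore estimated at 550 nM in this assay, likely between 250 nM and 1300 nM.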

Compound 4, half-maximal inhibitory concentration: 5600 nM
Compound 4: the middle estimate sits 10-fold (1.01 log units) below what was measured; the whole stated range lies below it.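

On the second core, dimethylamino in place of amino went the other way in this assay with a 3.9-fold higher number from compound 3 to compound 4 (0.59 log units; beyond the scatter) as its result. Set beside the earlier step, the same change did not carry over from one core to the other: the same change on two cores in this assay, a 2.9-fold lower number (0.46 log units; beyond the scatter) from compound 1 to compound 2 and a 3.9-fold higher number (0.59 log units; beyond the scatter) from compound 3 to compound 4, 11-fold (1.04 log units) apart, beyond the scatter of two such steps. So within this series, the step seen on one core gave no guide to its direction on the other, but two cores cannot show how the change would behave on a further core, and these values do not explain why the steps part.

From the compounds shown here alone, it remains open whether a methylamino group, intermediate between the two groups compared, would follow the trend of either core. The same question stands for a ring amine such as pyrrolidine or morpholine in that place.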